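Catechol vinyl sulfones: a ring replaces the hydroxylated chain

The source may report more compounds than this note shows. Statements on the series, on what has been measured and on what is new or still open speak of the compounds shown alone.

Compound 1 `CCCCCCCS(=O)(=O)/C=C/c1ccc(O)c(O)c1` gives 7100 nM in a functional assay, read by fluorescence and spectrophotometry, with a stated time of 1 h; a lower number here means that less compound is needed, a higher number that more compound is needed for the effect.
Compound 2 `C=CCCCCCS(=O)(=O)/C=C/c1ccc(O)c(O)c1` gives 7100 nM in this assay.
Compound 3 `O=S(=O)(/C=C/c1ccc(O)c(O)c1)CCCCCCCCO` gives 6700 nM in this assay.

Compound 3 has the lowest of the three numbers, but its steps to compound 1 and compound 2 are both within the scatter, so the three compounds are indistinguishable on these data. Compound 4 `O=S(=O)(/C=C/c1ccc(O)c(O)c1)CCCC1CCCCC1` is the next member of the series. The change from compound 3 is cyclohexyl in place of 5-hydroxypentyl on a saturated chain carbon, three bonds along the chain from a sulfonyl sulfur.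

Within the data shown here, three measured steps bear on this. The step of a 1.1-fold lower number from compound 1 to compound 3 (0.03 log units; within the scatter) shows that adding a hydroxyl at the far end of the chain leaves the number unchanged; the steps of no change at the digits printed from compound 1 to compound 2 (within the scatter) and a 1.1-fold lower number from compound 2 to compound 3 (0.03 log units; within the scatter) likewise show that the tail of the chain can be altered without effect. Among the measured compounds shown here, no measured step covers a ring in place of an open chain, so the cyclohexyl itself is untested.

On that basis compound 4 is expected to show essentially no change, with an estimated step of a 1.0-fold higher number from compound 3 to compound 4 (0.02 log units; within the scatter). The estimated value for compound 4 is 7000 nM, within a range of 3000 nM to 16000 nM.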

Compound 4, half-maximal effective concentration: 7900 nM
Compound 4: the middle estimate sits 1.1-fold (0.05 log units) below what was measured; the measured number falls inside the stated range.
By their numbers in this assay, from the lowest: compounds 3, 1, 2 and 4 (each within the scatter of the next).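

In this assay a closed ring at this place, three bonds along the chain from a sulfonyl sulfur, cannot be told apart from any of the open chains: the steps are a 1.2-fold higher number from compound 3 to compound 4 (0.07 log units; within the scatter) and a 1.1-fold higher number from compound 2 to compound 4 (0.05 log units; within the scatter) and also a 1.1-fold higher number from compound 1 to compound 4 (0.05 log units; within the scatter) in this assay. Cyclohexyl can therefore stand in place of 5-hydroxypentyl, losing the hydroxyl of compound 3 along with the open chain, and all four numbers still lie within the scatter of one another. Nothing available explains this result or says what the ring does here.

The compounds shown leave open whether any group at this place can move the number beyond the scatter, such as an amine or a carboxylic acid at the end of the chain. They also leave open how a phenyl ring or a much shorter chain would compare with cyclohexyl.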